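Replacing one group of compound 2 with amino

A few compounds are considered here, and "the series" means these few. Any claim that something is new, unique, unknown or untested is made for them only; others in the source may bear on it.

Going by the values given here, in a functional assay on HeLa cells (Homo sapiens) for cytotoxicity, read by MTT assay (on this read-out higher numbers stand for weaker inhibition and lower numbers for stronger inhibition), compound 2 (`COc1ccc(C2CC2c2cc(OC)c(OC)c(OC)c2)cc1OP(=O)(O)O`) gives 370 nM, the lower of the two exact numbers so far. Compound 1 (`COc1ccc(C#Cc2cc(OC)c(OC)c(OC)c2)cc1O`) gives a higher number, 1540 nM, and that gap lies beyond the scatter. Compound 3 (`COc1ccc(C#Cc2cc(OC)c(OC)c(OC)c2)cc1NC(=O)OC(C)(C)C`) gives > 30000 nM, which is a limit of the assay and not an exact number.

The next compound to be measured is compound 4 (`COc1ccc(C2CC2c2cc(OC)c(OC)c(OC)c2)cc1N`), and the change from compound 2 is one nitrogen atom in place of a group of 5 heavy atoms (4 oxygen, 1 phosphorus; no ring), on an aromatic carbon. It sits on an aromatic carbon, ortho to a methoxy group. Among the compounds with values here, the one measured step that alters a group on such a carbon is an at least 19-fold higher number from compound 1 to compound 3 (1.28 log units; beyond the scatter), which puts (tert-butoxycarbonyl)amino in place of hydroxy. That step is large and points to weaker inhibition, but it ends at a limit: the limit of > 30000 nM in this assay, at which 1 of the 3 values shown sits. It is only a weak guide here, since it involves neither the plain amino group nor the group that leaves, and the core of compound 1 differs from that of compound 2. No step beyond the scatter can therefore be expected in either direction. The expected change is a 1.5-fold lower number from compound 2 to compound 4 (0.17 log units; within the scatter), with wide uncertainty. For compound 4 the estimated value in this assay is 250 nM, within an expected range of 25 nM to 2500 nM.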

Compound 4, half-maximal inhibitory concentration: 41 nM
The estimate for compound 4 lay 6.1-fold (0.79 log units) above the measured number; measured number inside the range.
By their numbers in this assay, from the lowest: compound 4; then compound 2; then compound 1. At a limit, above all of these: compound 3.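

In this assay, going by these compounds alone, the exchange gives a 9.0-fold lower number from compound 2 to compound 4 (0.96 log units; beyond the scatter), so the plain amino group on this aromatic carbon, ortho to a methoxy group, is the first change at this place seen to move toward stronger inhibition. The earlier step, an at least 19-fold higher number from compound 1 to compound 3 (1.28 log units; beyond the scatter), ran the other way on a different core, so across the compounds shown a change at this place can move the number in either direction. In that earlier step, compound 3 gives > 30000 nM, which is a limit of the assay and not an exact number.

The compounds shown offer no measured property that would account for the step to compound 4. Still open, as far as these compounds go, is how a hydroxy group would read on the core of compound 4 and a plain amino group on the core of compound 1, and whether an acetamide or a dimethylamino group at this place would keep the number of compound 4, which would show whether the free amino group itself matters.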